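The source may report more compounds than this note shows. Statements on the series, on what has been measured and on what is new or still open speak of the compounds shown alone.

In a functional assay on K562 cells (Homo sapiens) for inhibition, read by trypan blue exclusion, with a stated time of 48 h (on this read-out higher numbers stand for weaker inhibition and lower numbers for stronger inhibition), compound 1 `NC(=O)c1cc(Br)ccc1NC(=O)/C=C/c1ccccc1` gives 5000 nM and compound 2 `Cc1ccc(/C=C/C(=O)Nc2ccc(Cl)cc2C(N)=O)cc1` gives 6300 nM. These two values lie within the usual scatter of each other, so neither compound stands apart. Compound 3 `NC(=O)c1cc(Br)ccc1NC(=O)/C=C/c1ccccc1Br` has not yet been measured. It differs from compound 1 by bromo in place of hydrogen on an aromatic carbon, ortho to a large group (bromo in place of hydrogen on an aromatic carbon). Among the measured compounds shown here, no measured pair shows this change, so only a modest shift toward stronger inhibition is expected. The expected change is a 1.7-fold lower number from compound 1 to compound 3 (0.22 log units; within the scatter). For compound 3 the estimated value is 3000 nM, with an expected range from 900 nM to 10000 nM.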

Compound 3, half-maximal inhibitory concentration: > 10000 nM
Compound 3 was reported as a limit (the forecaster's own chance of this, stated with the estimate: 5%); at least 3.3-fold (0.52 log units) between middle value and limit.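

In this assay, compound 3 gives > 10000 nM, which is a limit of the assay and not a number. Bromo in place of hydrogen on this aromatic carbon, ortho to a large group, gives an at least 2.0-fold higher number from compound 1 to compound 3 (0.30 log units; that floor lies within the scatter), so this change brings no gain in inhibition here, though the floor alone does not establish a loss. The step has a floor but no measured size: the limit of > 10000 nM in this assay, at which 1 of the 3 values shown sits.

From the compounds shown here alone, whether fluoro or an amine on this same carbon would behave differently stays open. So does the effect of bromo on another carbon of this ring.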